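A bromo-to-fluoro swap at the assay limit

The source may report more compounds than this note shows. Statements on the series, on what has been measured and on what is new or still open speak of the compounds shown alone.

Measured in a functional assay on MCF7 cells (Homo sapiens) for cytotoxicity, read by MTT assay, with a stated time of 72 h; on this read-out lower numbers stand for stronger inhibition and higher numbers for weaker inhibition (each value is a limit of the assay, not a number):
Compound 1 `CNC(=O)c1cc(Oc2ccc(NC(=O)c3cc(-c4ccc(Cl)cc4)ncn3)cc2F)ccn1` gives > 100000 nM (a limit)
Compound 2 `CNC(=O)c1cc(Oc2ccc(NC(=O)c3cc(-c4ccc(Br)cc4)ncn3)cc2)ccn1` gives > 100000 nM (a limit)
Compound 3 `CNC(=O)c1cc(Oc2ccc(NC(=O)c3cc(-c4ccc(Br)cc4)ncn3)cc2F)ccn1` gives > 100000 nM (a limit)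

Compound 3 has no number of its own, only the limit > 100000 nM in this assay and so it cannot be placed above or below the other two compounds.

Compound 4 `CNC(=O)c1cc(Oc2ccc(NC(=O)c3cc(-c4ccc(F)cc4)ncn3)cc2F)ccn1` differs from compound 3 in one place, fluoro in place of bromo on an aromatic carbon, so that 4-bromophenyl becomes 4-fluorophenyl. Within the data shown here, two measured steps bear on this change. The closer one is a step that the two limits leave unreadable from compound 1 to compound 3 (bromo in place of chloro on an aromatic carbon), and the other is a step that the two limits leave unreadable from compound 2 to compound 3 (fluoro in place of hydrogen on an aromatic carbon). Neither size can be read, so the expectation in this assay rests on the limit of > 100000 nM in this assay, at which 3 of the 3 values shown sit, and is for no clear step in either direction.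

The estimated a number no higher from compound 3 to compound 4 (the limit leaves the size open) is therefore expected to be small. Compound 4 is expected near 100000 nM with an estimated range of 30000 nM to 200000 nM and will most likely be reported as a limit again.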

Compound 4, half-maximal inhibitory concentration: > 100000 nM
Compound 4 was reported as a limit (the forecaster's own chance of this, stated with the estimate: 85%); the middle value lies on the limit itself.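

Compound 4 gives only a limit, not a number, so its steps from compound 3 and from compound 1 cannot be read in this assay: the limit of > 100000 nM in this assay, at which 4 of the 4 values shown sit. The compounds shown leave open whether fluoro, chloro or bromo at this place makes any real difference to the read-out.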